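Naphthyl in Place of Cyanophenyl on the Piperazine Nitrogen

A few compounds are considered here, and "the series" means these few. Any claim that something is new, unique, unknown or untested is made for them only; others in the source may bear on it.

Compound 1 `COc1ccc(NC(=O)c2ccc(-c3ccc(C4=NC(C)ON4)cc3C)cc2)cc1N1CCN(C)CC1`: 0.14 nM
Compound 2 `CN1CCN(c2cccc3ccc(OCC(=O)N4CCN(c5ccccc5C#N)CC4)cc23)CC1`: 0.38 nM

Of the compounds shown here, two have been measured in an assay on COS-7 cells for binding affinity to 5-hydroxytryptamine receptor 1B (Homo sapiens); a lower number here means a stronger inhibitor, a higher number a weaker inhibitor. In this assay compound 1 gives 0.14 nM. Compound 2 gives 0.38 nM in this assay, the higher of the two numbers, and the gap to compound 1 lies beyond the usual scatter, so compound 1 is the stronger binder of the pair. Both, however, bind very tightly.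

Compound 3 `CN1CCN(c2cccc3ccc(OCC(=O)N4CCN(c5cccc6ccccc56)CC4)cc23)CC1` keeps the whole core of compound 2 and differs from it in one place: naphthalen-1-yl in place of 2-cyanophenyl on an amine nitrogen in a ring. Within the data shown here, no pair of measured compounds shows this same change, so there is no measured step to lean on. Because compound 2 already gives 0.38 nM in this assay, and the change touches only the group on the ring nitrogen, the expectation is a small step, a 1.3-fold lower number from compound 2 to compound 3 (0.10 log units; within the scatter), not clearly beyond the scatter and, if anything, toward a slightly lower number. For compound 3 the estimated value in this assay is 0.3 nM, with a range from 0.08 nM to 1.2 nM.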

Compound 3, inhibition constant: 0.43 nM
Estimate against measurement, compound 3: 1.4-fold (0.16 log units) below, and the stated range covers the measured number.
By their numbers in this assay, from the lowest: compound 1; then compounds 2 and 3 (each within the scatter of the next).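

On the amine nitrogen in the ring, naphthalen-1-yl in place of 2-cyanophenyl gives a 1.1-fold higher number from compound 2 to compound 3 (0.05 log units; within the scatter) in this assay, so this read-out does not tell the two groups apart at this position. On paper the change is not a small one: the nitrile with its one hydrogen-bond acceptor leaves and a second six-membered aromatic ring of carbon only enters, yet compound 3 stays within the scatter of compound 2. No measurement at hand explains why these two different groups give such closely matching numbers.

The nitrile and the second ring change in a single move, so this one step cannot show what either does alone, and a plain phenyl group on the same nitrogen would help to separate the two. On these data alone, how far this match extends also remains open, for example to a small methyl group, to a pyridin-2-yl ring with nitrogen in the ring, or to a 2-methoxyphenyl group.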